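A few compounds are considered here, and "the series" means these few. Any claim that something is new, unique, unknown or untested is made for them only; others in the source may bear on it.

Three compounds have numbers in a functional assay on HepG2 cells (Homo sapiens) for inhibition, read by MTT assay, with a stated time of 48 h; a higher number here means a weaker inhibitor, a lower number a stronger inhibitor. Compound 1 (`COc1ccc(C(=O)C=CNc2cc(-c3ccccc3)nn2-c2ccccc2)cc1`) gives 2030 nM. Compound 3 (`N#Cc1c(-c2ccc(Cl)cc2)nc2c(c(-c3ccccc3)nn2-c2ccccc2)c1-c1ccc(N2CCCCC2)cc1`) gives 3210 nM, which lies within the usual scatter of the result for compound 1. Compound 2 (`Clc1ccc(-c2ccnc3c2c(-c2ccccc2)nn3-c2ccccc2)cc1`) gives 61100 nM, a much weaker result and well beyond the scatter from compound 1. Compound 1 therefore stands at the strong end of this small set, level with compound 3.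

Compound 4 (`O=C(C=CNc1cc(-c2ccccc2)nn1-c1ccccc1)c1ccccc1`) has not yet been measured. It differs from compound 1 in one place, with hydrogen in place of methoxy on an aromatic carbon, para to a large group (hydrogen in place of methoxy on an aromatic carbon). This turns the 4-methoxyphenyl into a phenyl. Within the data shown here, no two measured compounds differ by this change alone, so the data do not show what it does, and only a cautious expectation is possible: a small shift toward a weaker number, probably not beyond the scatter. The expected size of the change is a 1.5-fold higher number from compound 1 to compound 4 (0.17 log units; within the scatter). For compound 4 the estimated value is 3000 nM, with an expected range from 1000 nM to 9000 nM.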

Compound 4, half-maximal inhibitory concentration: 2660 nM
Compound 4: the middle estimate sits 1.1-fold (0.05 log units) above what was measured, within the range that was stated.
By their numbers in this assay, from the lowest: compounds 1, 4 and 3 (each within the scatter of the next); then compound 2.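

In this assay, replacing methoxy with hydrogen on the aromatic carbon para to a large group gives a 1.3-fold higher number from compound 1 to compound 4 (0.12 log units; within the scatter). This first direct test of the position therefore finds no change that can be told apart from ordinary variation between repeat measurements. Losing the methoxy group's two heavy atoms and its hydrogen-bond acceptor leaves the result in the same range, and nothing measured here speaks to the reason for this.

Methoxy and hydrogen are the only groups compared at this position, so it remains open whether a dimethylamino group, a carboxylic acid or a longer chain such as butoxy would move the number beyond the scatter. Also open, from the compounds shown here alone, is whether the same swap would behave alike on another core, as compound 2 and compound 3 differ from compound 1 in more than one place.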